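Trading 2-chlorophenyl for 3-nitrophenyl

The compounds below may be only part of what the source reports. "The series", "measured", "known", "first", "only" and "open" are said of these compounds alone.

In a functional assay, read by spectrophotometry, with a stated time of 30 min (a higher number here means a weaker inhibitor, a lower number a stronger inhibitor), compound 1 (`CC(C)(C)c1cc(/C=C/C(=O)NCCC2CCN(Cc3ccc(F)cc3)CC2)cc(C(C)(C)C)c1O`) gives 57500 nM and compound 2 (`CC(C)(C)c1cc(/C=C/C(=O)NCCC2CCN(Cc3ccccc3Cl)CC2)cc(C(C)(C)C)c1O`) gives 80200 nM. Repeat measurements of this kind naturally scatter, and these two values lie within that scatter of each other, so compound 2 cannot be ranked against compound 1.

Compound 3 (`CC(C)(C)c1cc(/C=C/C(=O)NCCC2CCN(Cc3cccc([N+](=O)[O-])c3)CC2)cc(C(C)(C)C)c1O`) has not yet been measured. It keeps the shared core and carries 3-nitrophenyl in place of 2-chlorophenyl on a saturated chain carbon bound to an amine nitrogen in a ring.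

Going by the values given here, only one measured step touches this place: a 1.4-fold higher number from compound 1 to compound 2 (0.14 log units; within the scatter). That single exchange of one substituted phenyl group for another did not move the number beyond the scatter. Among the compounds with values here, it is a thin guide, as no compound with a nitro group has a measured value yet. On this evidence, no change beyond the scatter is expected in this assay, and the estimated step is a 1.2-fold lower number from compound 2 to compound 3 (0.09 log units; within the scatter). For compound 3 the estimated value is 65000 nM, with an expected range from 28000 nM to 150000 nM.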

Compound 3, half-maximal inhibitory concentration: 78100 nM
For compound 3 the middle estimate is 1.2-fold (0.08 log units) below the measured one; measured number inside the range.
By their numbers in this assay, from the lowest: compounds 1, 3 and 2 (each within the scatter of the next).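

In this assay, the exchange of 2-chlorophenyl for 3-nitrophenyl gives a 1.0-fold lower number from compound 2 to compound 3 (0.01 log units; within the scatter) and the exchange of 4-fluorophenyl for 3-nitrophenyl gives a 1.4-fold higher number from compound 1 to compound 3 (0.13 log units; within the scatter) at the same place. Going by these compounds alone, the earlier pair covered only two halogen-bearing phenyl groups, whereas this position, on a saturated chain carbon bound to an amine nitrogen in a ring, now also holds a nitro-bearing one, and compounds 1, 2 and 3 all lie within the scatter of each other. The change is also a bigger one by simple counting, going from 7 heavy atoms and 0 hydrogen-bond acceptors in 2-chlorophenyl to 9 heavy atoms and 2 hydrogen-bond acceptors in 3-nitrophenyl, yet no step beyond the scatter appears.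

No separate measurement is available to account for this flat result. Going by these compounds, it remains open whether a phenyl group carrying an amine or a carboxylic acid, or a longer chain in place of the benzyl group, would move the number beyond the scatter.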